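Thioether esters on the shared core: compound 4

The source may report more compounds than this note shows. Statements on the series, on what has been measured and on what is new or still open speak of the compounds shown alone.

Measured so far in a functional assay on NCI-H1975 cells (Homo sapiens) for inhibition, read by MTT assay, with a stated time of 72 h; on this read-out lower numbers stand for stronger inhibition and higher numbers for weaker inhibition:
compound 1 `CCOc1cc2ncnc(Nc3ccc(F)c(Cl)c3)c2cc1OC(=O)CCl` — compound 1 gives 60 nM
compound 2 `CCOc1cc2ncnc(Nc3ccc(F)c(Cl)c3)c2cc1OC(=O)CSc1ccccn1` — compound 2 gives 3700 nM
compound 3 `CCOc1cc2ncnc(Nc3ccc(F)c(Cl)c3)c2cc1OC(=O)CSc1nnnn1C` — compound 3 gives 2100 nM

Compound 3 stands second highest of the three numbers. Its nearest neighbour is compound 2, and the step of a 1.8-fold lower number from compound 2 to compound 3 (0.25 log units; within the scatter) is within the scatter, so the two are not ordered. The far compound is compound 1, and the step of a 35-fold higher number from compound 1 to compound 3 (1.54 log units; beyond the scatter) is large and beyond the scatter.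

Compound 4 `CCOc1cc2ncnc(Nc3ccc(F)c(Cl)c3)c2cc1OC(=O)CSc1nc2ccccc2s1` is the next candidate. The change from compound 3 is 1,3-benzothiazol-2-yl in place of 1-methyl-1H-tetrazol-5-yl on a sulfur; a sulfanyl attached to a saturated chain carbon bound to a carbonyl carbon is kept, and only the aromatic group on that sulfur is swapped.

Within the data shown here, two measured steps bear on this. The steps of a 62-fold higher number from compound 1 to compound 2 (1.79 log units; beyond the scatter) and a 35-fold higher number from compound 1 to compound 3 (1.54 log units; beyond the scatter) show that placing an aryl group on the sulfur, either pyridin-2-yl or 1-methyl-1H-tetrazol-5-yl, gives a large rise in this assay relative to the chloro parent. Between the two aryl groups themselves, a 1.8-fold lower number from compound 2 to compound 3 (0.25 log units; within the scatter) is within the scatter. For a third aryl group on the same sulfur, no step beyond the scatter is therefore expected; the estimated step is a 1.2-fold higher number from compound 3 to compound 4 (0.08 log units; within the scatter). For compound 4 the expected value in this assay is 2500 nM, with a range from 800 nM to 8000 nM.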

Compound 4, half-maximal inhibitory concentration: 9800 nM
The estimate for compound 4 lay 3.9-fold (0.59 log units) below the measured number; measured number outside the range, above it.
By their numbers in this assay, from the lowest: compound 1; then compounds 3 and 2 (each within the scatter of the next); then compound 4.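

In this assay, the choice of aromatic group on the sulfur now makes a difference among the thioether esters. With 1,3-benzothiazol-2-yl, the number rises by a 4.7-fold higher number from compound 3 to compound 4 (0.67 log units; beyond the scatter) and by a 2.6-fold higher number from compound 2 to compound 4 (0.42 log units; beyond the scatter), both modest steps, whereas pyridin-2-yl and 1-methyl-1H-tetrazol-5-yl could not be ordered, at a 1.8-fold lower number from compound 2 to compound 3 (0.25 log units; within the scatter). The distance from the chloro parent also widens to a 160-fold higher number from compound 1 to compound 4 (2.21 log units; beyond the scatter), so all three sulfanyl replacements of chloro on the saturated chain carbon bound to a carbonyl carbon go the same way, with none against that pattern, and no measurement at hand gives a reason for the rise with 1,3-benzothiazol-2-yl.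

Going by these compounds, with only aromatic groups on the sulfur, it remains open whether a plain methyl or a carboxylic acid-bearing chain there would read near compound 3 or move back toward compound 1. On these data alone, it is also open how an amine or a methoxy in place of chloro on the saturated chain carbon would compare with compound 1, which would show whether the sulfur itself matters to the large steps.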